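Swapping One Aromatic Ring in an Antiproliferative Series

The source may hold more compounds than are shown below. What is called first, only, known or untested is meant among the compounds shown, and "the series" means these compounds.

Compound 1 `COc1cc(-c2c(C)nn(-c3nc(-c4ccc(Cl)c(Cl)c4)c(SC(C)C)s3)c2C(=O)O)cc(C(F)(F)F)c1` is one of three compounds tested in a functional assay on BJAB cells (Homo sapiens) for antiproliferative activity, with a stated time of 4 days (a higher number here means that more compound is needed for the effect, a lower number that less compound is needed), where compound 1 gives 1380 nM, the lowest of the three numbers. Compound 2 `Cc1nn(-c2nc(-c3ccc(Cl)c(Cl)c3)c(SC(C)C)s2)c(C(=O)O)c1-c1cncnc1` gives 22000 nM, and compound 3 `Cc1ccccc1-c1c(C)nn(-c2nc(-c3ccc(Cl)c(Cl)c3)c(SC(C)C)s2)c1C(=O)O` gives 5500 nM. The step of a 16-fold higher number from compound 1 to compound 2 (1.20 log units; beyond the scatter) and the step of a 4.0-fold higher number from compound 1 to compound 3 (0.60 log units; beyond the scatter) both show that replacing the 3-methoxy-5-(trifluoromethyl)phenyl ring of compound 1 has so far led to a higher number, by a large amount for one replacement and a modest amount for the other. Compound 4 `Cc1cc(Cl)cc(-c2c(C)nn(-c3nc(-c4ccc(Cl)c(Cl)c4)c(SC(C)C)s3)c2C(=O)O)c1` has not yet been measured; it differs from compound 1 in one place: 3-chloro-5-methylphenyl in place of 3-methoxy-5-(trifluoromethyl)phenyl on an aromatic carbon. Among the measured compounds shown here, the entering ring, like the one it replaces, is a six-membered aromatic ring of carbon only carrying two groups, so the change resembles the one toward compound 3 more than the one toward compound 2. For compound 4 a modest step up is expected, a 1.8-fold higher number from compound 1 to compound 4 (0.26 log units; within the scatter), possibly within the scatter. Compound 4 is estimated at 2500 nM in this assay, with a range from 900 nM to 7000 nM.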

Compound 4, half-maximal effective concentration: 663 nM
Estimate against measurement, compound 4: 3.8-fold (0.58 log units) above, outside the stated range (below it).
By their numbers in this assay, from the lowest: compound 4; then compound 1; then compound 3; then compound 2.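

This position does not only tolerate changes that raise the number. In this assay the 3-chloro-5-methylphenyl ring gives a 2.1-fold lower number from compound 1 to compound 4 (0.32 log units; beyond the scatter), making it the only one of the three replacements to lower the number from that of compound 1, even though it has fewer heavy atoms and no hydrogen-bond acceptor. The same ring gives an 8.3-fold lower number from compound 3 to compound 4 (0.92 log units; beyond the scatter) and also a 33-fold lower number from compound 2 to compound 4 (1.52 log units; beyond the scatter), so the choice of ring at this one position spans a wide range of numbers, and nothing available explains this.

The compounds shown leave open whether the chlorine or the methyl group accounts for the lower number of compound 4. They also leave open what a ring carrying an amine or a nitrile would give here.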